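Pyrrolidine in place of the cyanomethyl amine

This account rests on a few compounds, and the source may have more. Where it says the series, first, only, none or still open, it means among the compounds named here.

Compound 2 `CCCC(=O)Nc1ccc(-c2nc3n(Cc4ccccc4F)cc(C(=O)OC(CC)CC)c(=O)n3c2CN(C)CC#N)cc1` holds the lowest of the two numbers in an assay on isolated protein for agonist activity at Gonadotropin-releasing hormone receptor (Homo sapiens) (a lower number here means a stronger inhibitor, a higher number a weaker inhibitor), where compound 2 gives 300 nM. Compound 1 `CCCC(=O)Nc1ccc(-c2cn3c(=O)c(C(=O)OC(CC)CC)cn(Cc4ccccc4F)c3n2)cc1`, which lacks the whole substituent on the saturated chain carbon bound to an aromatic carbon, gives 28000 nM. Within the data shown here, the single step in hand, a 93-fold lower number from compound 1 to compound 2 (1.97 log units; beyond the scatter), shows how strongly that substituent matters. Compound 3 `CCCC(=O)Nc1ccc(-c2nc3n(Cc4ccccc4F)cc(C(=O)OC(CC)CC)c(=O)n3c2CN2CCCC2)cc1` keeps the substituent and changes only its end: pyrrolidin-1-yl in place of (cyanomethyl)(methyl)amino on a saturated chain carbon bound to an aromatic carbon. Among the measured compounds shown here, no measured step bears on this exchange; the step from compound 1 to compound 2 concerns adding the group as a whole, not swapping one amine for another, so it sets no size for the present change. With nothing to point either way, compound 3 is expected to stay close to compound 2 in this assay, a change of no change at the digits printed from compound 2 to compound 3 (within the scatter), and is estimated at 300 nM, within 90 nM to 1000 nM.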

Compound 3, inhibition constant: 2200 nM
Estimate against measurement, compound 3: 7.3-fold (0.87 log units) below, outside the stated range (above it).
By their numbers in this assay, from the lowest: compound 2; then compound 3; then compound 1.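

In this assay the exchange of (cyanomethyl)(methyl)amino for pyrrolidin-1-yl on a saturated chain carbon bound to an aromatic carbon gives a 7.3-fold higher number from compound 2 to compound 3 (0.87 log units; beyond the scatter) and so shows that the end of this substituent matters, not only its presence. The (pyrrolidin-1-yl)methyl group still improves on hydrogen, with a 13-fold lower number from compound 1 to compound 3 (1.10 log units; beyond the scatter) in the same assay, so both amines give a gain over compound 1, and the gain is larger with compound 2. Nothing measured here accounts for the difference between the two amines.

On these data alone, whether the nitrile carries this difference stays open, and a methyl(propyl)amino group in its place would bear on that. Also open, as far as these compounds go, is where other amines on this carbon, such as morpholine, piperidine or dimethylamino, would fall relative to compound 2 and compound 3.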